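A few compounds are considered here, and "the series" means these few. Any claim that something is new, unique, unknown or untested is made for them only; others in the source may bear on it.

Compound 1 `COc1nn(C)c2ncnc(NS(=O)(=O)c3cccc(Cl)c3Cl)c12` stands at the lowest of the two numbers in a functional assay on cells for antagonist activity at C-C chemokine receptor type 4 (Homo sapiens), read by GTPgammaS binding (on this read-out lower numbers stand for stronger inhibition and higher numbers for weaker inhibition), where compound 1 gives 63.1 nM. Compound 2 `COc1nn(CC(=O)O)c2ncnc(NS(=O)(=O)c3cccc(Cl)c3Cl)c12` gives 200 nM. For the measured compounds named here, the only measured step is a 3.2-fold higher number from compound 1 to compound 2 (0.50 log units; beyond the scatter), which alters a saturated chain carbon bound to an aromatic nitrogen. Compound 3 `COc1nn(C)c2nc(NC3COC3)nc(NS(=O)(=O)c3cccc(Cl)c3Cl)c12` differs from compound 1 by (oxetan-3-yl)amino in place of hydrogen on an aromatic carbon. Going by the values given here, this aromatic carbon is untouched in the measured pair, so no measured step bears on the change and no direction can be read from the series. For compound 3 the expected value in this assay is 50 nM, with a range from 12 nM to 250 nM. The expected step is therefore a 1.3-fold lower number from compound 1 to compound 3 (0.10 log units; within the scatter).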

Compound 3, half-maximal inhibitory concentration: 10000 nM
Beside the measured number, compound 3's estimate is 200-fold (2.30 log units) below it; measured number outside the range, above it.
By their numbers in this assay, from the lowest: compound 1; then compound 2; then compound 3.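

Unlike the modest step at the saturated chain carbon, a 3.2-fold higher number from compound 1 to compound 2 (0.50 log units; beyond the scatter), the aromatic carbon between two ring nitrogen atoms shows a large response in this assay: (oxetan-3-yl)amino in place of hydrogen gives a 160-fold higher number from compound 1 to compound 3 (2.20 log units; beyond the scatter). So this position does not accept every substituent, and this group weakens inhibition sharply on the core of compound 1. Nothing available here explains the step. Going by these compounds, whether a plain amino group or a methyl group at this carbon would weaken inhibition as strongly remains open.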